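A few compounds are considered here, and "the series" means these few. Any claim that something is new, unique, unknown or untested is made for them only; others in the source may bear on it.

Measured so far in a functional assay on MT4 cells (Homo sapiens) for cytotoxicity, read by MTT assay; a higher number here means that more compound is tolerated, a lower number that less compound is tolerated:

compound 1 `COc1ccc(CCSc2nc(Cc3c(Cl)cccc3Cl)c(C)c(=O)[nH]2)cc1`: > 57000 nM
compound 2 `COc1ccc(CCCSc2nc(O)c(C)c(Cc3c(Cl)cccc3Cl)n2)cc1`: 1000 nM
compound 3 `Cc1c(O)nc(SCc2cccc(F)c2)nc1Cc1c(Cl)cccc1Cl`: > 61000 nM

Compound 1 stands at a limit of the assay and not at a number: the limit of > 57000 nM in this assay, at which 1 of the 3 values shown sits. Compound 3 also gives only a limit, (the limit of > 61000 nM in this assay, at which 1 of the 3 values shown sits). Compound 2 is the only one of the three with a true number, 1000 nM.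

Compound 4 `COc1ccc(CSc2nc(Cc3c(Cl)cccc3Cl)c(C)c(=O)[nH]2)cc1` keeps the core of compound 1 and changes one group, with 4-methoxyphenyl in place of 4-methoxybenzyl on a saturated chain carbon bound to a sulfur. Among the compounds with values here, no measured pair isolates this change. In this assay no step beyond the scatter is expected, and the reading may well be a limit again. That expectation rests on compound 1 at > 57000 nM, while compound 2 at 1000 nM keeps the expected range wide on the low side. The estimated change is an at least 1.1-fold lower number from compound 1 to compound 4 (0.05 log units; that floor lies within the scatter). For compound 4 the estimated value is 50000 nM, with an expected range of 10000 nM to 100000 nM.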

Compound 4, half-maximal cytotoxic concentration: 32000 nM
The estimate for compound 4 lay 1.6-fold (0.19 log units) above the measured number; low and high end bracket the measured number.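

In this assay compound 4 gives a true number, 32000 nM, so this position now has a measured reading on the core of compound 1, where compound 1 itself offers none. The change from 4-methoxybenzyl to 4-methoxyphenyl on a saturated chain carbon bound to a sulfur amounts to an at least 1.7-fold lower number from compound 1 to compound 4 (0.25 log units; that floor lies within the scatter), and a floor within the scatter does not establish a change beyond it. The step remains a floor because compound 1 gives only a limit: the limit of > 57000 nM in this assay, at which 1 of the 4 values shown sits.

The compounds shown leave open how large this step truly is. They also leave open how the number would respond to an amine or a carboxylic acid in place of 4-methoxyphenyl at this position.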